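A few compounds are considered here, and "the series" means these few. Any claim that something is new, unique, unknown or untested is made for them only; others in the source may bear on it.

Measured so far in an assay on isolated protein for inhibition of cathepsin S (Homo sapiens); on this read-out higher numbers stand for weaker inhibition and lower numbers for stronger inhibition:
compound 1 `COc1cccc(C(=O)N[C@@H](CCC2CCCCC2)C(=O)NCCN2CCc3cc(F)ccc32)c1` gives 2130 nM
compound 2 `COc1cccc(C(=O)N[C@@H](CCC2CCCCC2)C(=O)N[C@@H](COCc2ccccc2)CN2CCc3cc(F)ccc32)c1` gives 23 nM
compound 3 `COc1cccc(C(=O)N[C@@H](CCC2CCCCC2)C(=O)N[C@@H](CO)CN2CCc3cc(F)ccc32)c1` gives 50 nM

Compound 3 sits second highest of the three numbers in this assay, with compound 2 the nearest and compound 1 the furthest. The next compound, compound 4 `COc1cccc(C(=O)N[C@@H](CCC2CCCCC2)C(=O)N[C@H](CN2CCc3cc(F)ccc32)[C@@H](C)O)c1`, differs from compound 3 by methyl in place of hydrogen on a saturated chain carbon bound to an oxygen on a saturated carbon and a saturated chain carbon. Among the compounds with values here, two measured steps bear on this region. Putting hydroxymethyl in place of hydrogen on the saturated chain carbon bound to the amide-type nitrogen gave a 43-fold lower number from compound 1 to compound 3 (1.63 log units; beyond the scatter); putting hydrogen in place of benzyl on the oxygen of that group gave a 2.2-fold higher number from compound 2 to compound 3 (0.34 log units; beyond the scatter). Within the data shown here, neither step places anything on the saturated chain carbon bound to the oxygen, so there is no direct precedent for a methyl there, and the change is much smaller than either measured step. A step within the scatter, or at most a modest one, is therefore expected in this assay: a 1.3-fold lower number from compound 3 to compound 4 (0.10 log units; within the scatter). Compound 4 is estimated at 40 nM, with a range from 15 nM to 120 nM.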

Compound 4, inhibition constant: 8 nM
Beside the measured number, compound 4's estimate is 5.0-fold (0.70 log units) above it; measured number outside the range, below it.
By their numbers in this assay, from the lowest: compound 4; then compound 2; then compound 3; then compound 1.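

In this assay, within the data shown here, the saturated chain carbon bound to an oxygen proves responsive to substitution, which no earlier compound could show: a single methyl in place of hydrogen there gives a 6.3-fold lower number from compound 3 to compound 4 (0.80 log units; beyond the scatter). The 1-hydroxyethyl group also improves on (benzyloxy)methyl, with a 2.9-fold lower number from compound 2 to compound 4 (0.46 log units; beyond the scatter), and on the unsubstituted chain carbon, with a 270-fold lower number from compound 1 to compound 4 (2.43 log units; beyond the scatter), so compound 4 is the strongest inhibitor of the four and the benzyl group is not required for this level of inhibition. No supporting data bear on why the methyl has this effect.

Still open, as far as these compounds go, is whether a longer chain, such as ethyl in place of the methyl, extends or reverses this step. Also open, from the compounds shown here alone, are how much depends on the configuration at this carbon and whether an amine could replace the hydroxyl.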